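Tetrazole series: pyridin-2-yl replacing imidazol-2-yl

A few compounds are considered here, and "the series" means these few. Any claim that something is new, unique, unknown or untested is made for them only; others in the source may bear on it.

Going by the values given here, compound 1 `N#Cc1cccc(-n2nnc(-c3ncc[nH]3)n2)c1` gives 34 nM in an assay for binding affinity to metabotropic glutamate receptor 5 (Rattus norvegicus) (on this read-out lower numbers stand for stronger inhibition and higher numbers for weaker inhibition), the highest of the three numbers measured so far. Compound 2 `Cc1c[nH]c(-c2nnn(-c3cc(F)cc(C#N)c3)n2)n1` gives 19 nM, which sits within the scatter of compound 1. Compound 3 `N#Cc1cc(F)cc(-n2nnc(-c3ncc[nH]3)n2)c1` gives 9.3 nM; the step of a 3.7-fold lower number from compound 1 to compound 3 (0.56 log units; beyond the scatter) and the step of a 2.0-fold lower number from compound 2 to compound 3 (0.31 log units; beyond the scatter) are both beyond the scatter, so compound 3 has the lowest number of the three.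

Compound 4 `N#Cc1cccc(-n2nnc(-c3ccccn3)n2)c1` differs from compound 1 by pyridin-2-yl in place of 1H-imidazol-2-yl on an aromatic carbon. Neither measured step touches this part of the molecule: both concern substituents on the benzonitrile ring, not the group borne by the tetrazole. Among the compounds with values here, no measured pair therefore bears on the change, and the expectation rests on compound 1 alone with wide uncertainty.

Compound 4 is expected to give about 50 nM, in a range from 12 nM to 200 nM. The expected step of a 1.5-fold higher number from compound 1 to compound 4 (0.17 log units; within the scatter) is thus estimated as small and not clearly beyond the scatter, in either direction.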

Compound 4, inhibition constant: 102 nM
Compound 4: middle estimate off by 2.0-fold (0.31 log units), on the low side; low and high end bracket the measured number.
By their numbers in this assay, from the lowest: compound 3; then compounds 2 and 1 (each within the scatter of the next); then compound 4.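

Going by these compounds alone, at this position, on an aromatic carbon of the five-membered aromatic ring with 4 nitrogen, this assay shows a 3.0-fold higher number from compound 1 to compound 4 (0.48 log units; beyond the scatter) with pyridin-2-yl in place of 1H-imidazol-2-yl, so the group held here affects the read-out, which the earlier steps, both made elsewhere in the molecule, could not show. The change takes 5 heavy atoms to 6 heavy atoms, a five-membered ring to a six-membered ring and 1 hydrogen-bond donor to 0 hydrogen-bond donors all at once, and this single pair cannot separate these differences. No measurement at hand explains the step.

Open, as far as these compounds go, is whether fluoro on the aromatic ring of compound 4 would give a step like a 3.7-fold lower number from compound 1 to compound 3 (0.56 log units; beyond the scatter) in this series. Also open, from the compounds shown here alone, is how 1-methylimidazol-2-yl or phenyl would read here, as either would help separate ring size from the hydrogen-bond donor.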